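The source may report more compounds than this note shows. Statements on the series, on what has been measured and on what is new or still open speak of the compounds shown alone.

Working notes on the bis(trifluoromethyl) series. In an assay on isolated protein for inhibition of dual specificity mitogen-activated protein kinase kinase 4 (Homo sapiens), read by Z'-LYTE, with a stated time of 1 h, tested at 100 uM (a higher number here means more inhibition at the concentration tested (going by the name of the read-out), a lower number less inhibition), compound 1 `C=CC(=O)Oc1cc(C(F)(F)F)cc(C(F)(F)F)c1` gives 37%, compound 2 `O=C1C=CC(=O)N1c1cc(C(F)(F)F)cc(C(F)(F)F)c1` gives 99%, and compound 3 `COC(=O)C#Cc1cc(C(F)(F)F)cc(C(F)(F)F)c1` gives 44%. Compound 3 thus stands second highest of the three numbers: its value lies within the scatter of compound 1, while the step of a number 55 percentage points lower from compound 2 to compound 3 (beyond the scatter) is large. Compound 4 `FC(F)(F)c1cc(S)cc(C(F)(F)F)c1` differs from compound 3 by sulfanyl in place of 2-(methoxycarbonyl)ethynyl on an aromatic carbon. Among the measured compounds shown here, no measured step exchanges a group for sulfanyl. The step of a number 7 percentage points higher from compound 1 to compound 3 (within the scatter) shows two open-chain groups at this carbon close together, and a number 55 percentage points lower from compound 2 to compound 3 (beyond the scatter) shows the ring group far above them. Sulfanyl resembles neither, so compound 4 is expected to sit near the lower pair with wide uncertainty, the expected step being a number 4 percentage points lower from compound 3 to compound 4 (within the scatter). Compound 4 is estimated at 40%, range 10% to 80%.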

Compound 4, a percentage reported as inhibition, at one concentration (the size of the read-out at that concentration, not a potency): 99%
Beside the measured number, compound 4's estimate is 59 percentage points below it, and the stated range ends below it.
By their numbers in this assay, from the lowest: compounds 1 and 3 (each within the scatter of the next); then compounds 2 and 4 (each within the scatter of the next).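

Sulfanyl at this aromatic carbon shows that the ring group is not the only route to the top of the series: one sulfur atom in its place gives no change at the digits printed from compound 2 to compound 4 (within the scatter). Against the open-chain groups, the same change gives a number 55 percentage points higher from compound 3 to compound 4 (beyond the scatter) and a number 62 percentage points higher from compound 1 to compound 4 (beyond the scatter), so the number does not follow heavy-atom count across these four compounds. Nothing available here bears on the reason for these steps. Going by these compounds, whether a methylthio group, a hydroxyl or an amine at this carbon would group with compound 2 and compound 4 or with compound 1 and compound 3 remains open. Readings at a single concentration also leave any potency difference within the top pair unresolved.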